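Urea Variation on a Pyrazole Core: Predicting Growth Inhibition

The source may hold more compounds than are shown below. What is called first, only, known or untested is meant among the compounds shown, and "the series" means these compounds.

Of the compounds shown here, two from this series have been measured in a functional assay on Hs-578T cells (Homo sapiens) for inhibition, read by sulforhodamine B assay, with a stated time of 48 h, tested at 10 uM; on this read-out lower numbers stand for a stronger effect and higher numbers for a weaker effect at the one concentration tested. Compound 1 `COc1cc(Cl)cc(-c2nn(-c3cccc(NC(=O)Nc4cccc(C(F)(F)F)c4)c3)cc2-c2ccncc2)c1` gives 23.2% and stands highest of the two numbers. Among the compounds with values here, compound 2 `O=C(Nc1cccc(-n2cc(-c3ccncc3)c(-c3cc(O)cc(Cl)c3)n2)c1)Nc1ccc(Cl)c(Cl)c1` gives -6.42%, a number lower than that of compound 1 by a margin beyond the usual scatter; the two compounds differ in more than one place, so no single step between them is counted.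

Compound 3 `COc1cc(Cl)cc(-c2nn(-c3cccc(NC(=O)Nc4ccc(Cl)c(Cl)c4)c3)cc2-c2ccncc2)c1` has not yet been measured in this assay. It differs from compound 1 in one place: 3,4-dichlorophenyl in place of 3-(trifluoromethyl)phenyl on an amide-type nitrogen.

Within the data shown here, no measured pair shows the effect of this change alone. Since compound 2, which carries the same 3,4-dichlorophenyl group on its urea, gives -6.42%, a downward step is expected, estimated as a number 18.2 percentage points lower from compound 1 to compound 3 (beyond the scatter). Compound 3 is therefore expected to give about 5% in this assay, within a range of -20% to 30%.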

Compound 3, a percentage reported as activity, at one concentration (the size of the read-out at that concentration, not a potency): 28.5%
The estimate for compound 3 lay 23.5 percentage points below the measured number; the range from low to high includes it.
By their numbers in this assay, from the lowest: compound 2; then compounds 1 and 3 (each within the scatter of the next).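

In this assay the 3,4-dichlorophenyl group in place of 3-(trifluoromethyl)phenyl on the amide-type nitrogen gives a number 5.3 percentage points higher from compound 1 to compound 3 (within the scatter) and so leaves the two groups indistinguishable at this position on this read-out. The large gap seen earlier therefore goes with the other place: methyl in place of hydrogen on an oxygen on an aromatic ring gives a number 34.9 percentage points higher from compound 2 to compound 3 (beyond the scatter) with the 3,4-dichlorophenyl urea held constant. Nothing available explains either step.

On these data alone, whether an amine or a carboxylic acid on the urea's aromatic ring would move the number remains open. As far as these compounds go, it is also open whether the step on the oxygen holds alongside 3-(trifluoromethyl)phenyl, and what an ethyl group or a longer chain on that oxygen would give.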